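A Chloro Substituent Tried on Two Different Cores

The source may hold more compounds than are shown below. What is called first, only, known or untested is meant among the compounds shown, and "the series" means these compounds.

Compound 1 `O=C(/C=C/c1ccc(Cl)cc1)Nc1nc2ccccc2s1` and compound 3 `CC(=O)N1N=C(Nc2nc3ccccc3s2)CC1c1ccccc1` share part of their structure, but the difference between the two cores is not broken down here. In a functional assay on the whole organism (Hindlimb, strain albino) with Mus musculus as the target, in the maximal electroshock model, with a stated time of 0.5 h (on this read-out higher numbers stand for an effect only at larger amounts of compound and lower numbers for an effect already at smaller amounts), compound 1 gives 367 umol/kg, and compound 3 gives 315 umol/kg; the two numbers lie within the scatter of each other. Compound 2 `O=C(/C=C/c1ccc(Cl)cc1)Nc1nc2ccc(Cl)cc2s1` carries chloro in place of hydrogen on an aromatic carbon. In this assay compound 2 gives 204 umol/kg, and the step of a 1.8-fold lower number from compound 1 to compound 2 (0.26 log units; within the scatter) stays within the scatter.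

Compound 4 `CC(=O)N1N=C(Nc2nc3ccccc3s2)CC1c1ccc(Cl)cc1`, not yet measured, carries chloro in place of hydrogen on an aromatic carbon. This is the same kind of change as from compound 1 to compound 2, though the place differs: there the chloro sits on a ring that is part of a fused or bridged system of two rings, meta to a fused ring and para to a fused ring; here it sits on a six-membered aromatic ring of carbon only, para to a large group. The step from compound 3 to compound 4 is expected to be a 1.3-fold lower number from compound 3 to compound 4 (0.12 log units; within the scatter), a small shift, because a 1.8-fold lower number from compound 1 to compound 2 (0.26 log units; within the scatter) itself stayed within the scatter. Compound 4 is therefore estimated at 240 umol/kg, with a likely range from 120 umol/kg to 480 umol/kg.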

Compound 4, dose for half-maximal effect: 209 umol/kg
For compound 4 the middle estimate is 1.1-fold (0.06 log units) above the measured one, within the range that was stated.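

In this assay, the swap of phenyl to 4-chlorophenyl gives a 1.5-fold lower number from compound 3 to compound 4 (0.18 log units; within the scatter). Set beside the earlier chloro step, the result on this second core cannot be told apart from the first: the same change on two cores in this assay, a 1.8-fold lower number (0.26 log units; within the scatter) from compound 1 to compound 2 and a 1.5-fold lower number (0.18 log units; within the scatter) from compound 3 to compound 4, 1.2-fold (0.08 log units) apart, within the scatter of two such steps. The change therefore carries over between these two cores without a visible difference, but each step alone stays within the scatter, the chloro sits at a different place on each core, and two pairs set no rule for the series.

The compounds shown leave open whether another group in the same place, such as fluoro, methoxy or an amine, would give a step beyond the scatter. They also leave open how chloro would behave elsewhere on the phenyl ring.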